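The source may hold more compounds than are shown below. What is called first, only, known or untested is meant among the compounds shown, and "the series" means these compounds.

Working notes on the series. Compound 1 `CCOC(=O)CCCCCOc1cccc(CN(C(=O)c2ccc(-c3ccco3)cc2)C(C)C)c1`, compound 2 `CCOC(=O)CCCCCOc1cccc(CN(C(=O)c2ccc(-c3cccc(OC(F)(F)F)c3)cc2)C(C)C)c1` and compound 3 `CCOC(=O)CCCCCOc1cccc(CN(C(=O)c2ccc(-c3cccc(C(F)(F)F)c3)cc2)C(C)C)c1` share one core and differ only in the group carried on an aromatic carbon. In an ADME assay on Raji cells (Homo sapiens) for cytotoxicity, read by CellTiter-Glo and resazurin assay, with a stated time of 72 h (on this read-out lower numbers stand for an effect already at smaller amounts and higher numbers for an effect only at larger amounts of compound), compound 1 gives only a limit, > 26000 nM. Compound 2 also returns a limit in this assay, > 26000 nM. Compound 3 too stands at a limit in this assay, > 26000 nM, and so it sits level with the other two as far as the numbers reach. The steps a step that the two limits leave unreadable from compound 1 to compound 2, a step that the two limits leave unreadable from compound 1 to compound 3 and a step that the two limits leave unreadable from compound 2 to compound 3 therefore cannot be sized because of the limit of > 26000 nM in this assay, at which 3 of the 3 values shown sit.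

Compound 4 `CCOC(=O)CCCCCOc1cccc(CN(C(=O)c2ccc(-c3cccc(S(C)(=O)=O)c3)cc2)C(C)C)c1` is the next member. Against compound 3 the change is methylsulfonyl in place of trifluoromethyl on an aromatic carbon. Among the measured compounds shown here, no measured step in this assay has a readable size, so there is no basis for expecting movement in either direction beyond the scatter. The expected step is a step that the limit leaves unreadable from compound 3 to compound 4. Compound 4 is accordingly estimated at 40000 nM, with a range from 20000 nM to 100000 nM, most likely reported as a limit again.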

Compound 4, half-maximal effective concentration: > 26000 nM
Compound 4: only a limit was reported (the forecaster's own chance of this, stated with the estimate: 85%); the middle value does not contradict the limit.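

Compound 4 also gives only a limit in this assay, > 26000 nM. Among the compounds shown here, no step from compound 1, compound 2 or compound 3 to compound 4 can be read, because all four values are limits: the limit of > 26000 nM in this assay, at which 4 of the 4 values shown sit. The compounds shown leave open whether these four differ at all in this assay, and in which order.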